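A Larger Ester Group on a Weakly Active Pair

The source may hold more compounds than are shown below. What is called first, only, known or untested is meant among the compounds shown, and "the series" means these compounds.

In a functional assay on HCT-116 cells (Homo sapiens) for inhibition (on this read-out higher numbers stand for weaker inhibition and lower numbers for stronger inhibition), compound 1 `COc1ccc2oc(=O)cc(COC(=O)C=C(C)C)c2c1` gives > 10 ug/mL which is a limit of the assay and not a number. Compound 2 `C/C=C/C(=O)OCc1cc(=O)oc2cc(OC)c(OC)cc12` gives > 10 ug/mL which is likewise a limit. Compound 2 therefore has no exact number (the limit of > 10 ug/mL in this assay, at which 2 of the 2 values shown sit). Compound 3 `COc1cc2oc(=O)cc(COC(=O)/C=C/c3ccc(N)cc3)c2cc1OC` has 4-aminophenyl in place of methyl on a double-bonded chain carbon bound to a double-bonded chain carbon. Going by the values given here, no measured step guides this change, so the step of an at least 1.2-fold lower number from compound 2 to compound 3 (0.09 log units; that floor lies within the scatter) is only an estimate, expected as a modest strengthening of inhibition. In this assay compound 3 is expected at 8 ug/mL (estimated range 2.5 ug/mL to 20 ug/mL).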

Compound 3, half-maximal inhibitory concentration: > 10 ug/mL
Compound 3: only a limit was reported; the forecaster's own chance of this, stated with the estimate: 55%; middle value at least 1.2-fold (0.09 log units) away from the limit.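

Compound 2 and compound 3 both stand at a limit in this assay, so no step between them can be read: the limit of > 10 ug/mL in this assay, at which 3 of the 3 values shown sit.

The compounds shown leave open whether any ester group on the shared core gives inhibition that can be put as an exact number.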